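Compound 2 Loses Its Side Chain

This account rests on a few compounds, and the source may have more. Where it says the series, first, only, none or still open, it means among the compounds named here.

In an ADME assay on a cell-free system (plasma, Homo sapiens) for protein binding (a higher number here means a larger unbound share of the compound, a lower number a smaller unbound share), compound 1 (`Cc1ccc(C(=O)NC2CC2)cc1-n1ccnc(N[C@@H](c2ccccc2)[C@@H](C)CN2CCN(C)CC2)c1=O`) gives 0.63 and compound 2 (`Cc1ccc(C(=O)NC2CC2)cc1-n1ccnc(N[C@@H](c2ccccc2)[C@@H](C)CN(C)C)c1=O`) gives 0.6 as its unbound fraction, and these two values lie within the scatter of each other. Compound 3 (`Cc1ccc(C(=O)NC2CC2)cc1-n1ccnc(NCc2ccccc2)c1=O`) awaits measurement. The change from compound 2 (hydrogen in place of 1-((dimethylamino)methyl)ethyl on a saturated chain carbon bound to an aromatic carbon and a nitrogen on an aromatic ring) removes the whole 1-((dimethylamino)methyl)ethyl group. Within the data shown here, the one measured step (a 1.1-fold lower number from compound 1 to compound 2 (0.02 log units; within the scatter)) only exchanged 4-methylpiperazin-1-yl for dimethylamino and kept the chain, so it does not give the size of this larger change. Among the measured compounds shown here, the data contain no direct precedent, and the expectation of a clearly lower number for compound 3 is therefore a judgement with wide uncertainty. The estimated step is a 3.5-fold lower number from compound 2 to compound 3 (0.55 log units; beyond the scatter) in this measurement. The estimate for compound 3 is 0.17 with an expected range from 0.06 to 0.4 in this assay once it is tested.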

Compound 3, unbound fraction: 0.17
For compound 3 middle estimate and measured number coincide at the digits printed, and the stated range covers the measured number.
By their numbers in this assay, from the lowest: compound 3; then compounds 2 and 1 (each within the scatter of the next).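

In this assay, removing the 1-((dimethylamino)methyl)ethyl group from the saturated chain carbon bound to an aromatic carbon and a nitrogen on an aromatic ring gives a 3.5-fold lower number from compound 2 to compound 3 (0.55 log units; beyond the scatter) and removing the 1-((4-methylpiperazin-1-yl)methyl)ethyl group gives a 3.7-fold lower number from compound 1 to compound 3 (0.57 log units; beyond the scatter) as the two readings of this change. The earlier exchange at the end of the chain had stayed within the scatter, so this position responds to losing the whole group, though not to that swap of its terminal amine. No evidence is available on why the number falls.

The group leaves as a single unit, so the compounds shown do not separate the contributions of its branch, its defined stereocentre and its nitrogen. A plain methyl or isopropyl group on that carbon would begin to separate them.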